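Notes on compound 1 and the change to compound 3

A few compounds are considered here, and "the series" means these few. Any claim that something is new, unique, unknown or untested is made for them only; others in the source may bear on it.

Compound 1 `O=C(NS(=O)(=O)c1ccc(NC(=O)c2ccc(Cl)cc2Cl)cc1)c1ccccc1` stands without a number in a functional assay on HEK293 cells for agonist activity at probable G-protein coupled receptor 27 (Homo sapiens), read by a luciferase reporter and beta-arrestin recruitment, with a stated time of 10 min; on this read-out higher numbers stand for larger maximal responses and lower numbers for smaller maximal responses: compound 1 gives "not determined" (no result reported). Going by the values given here, compound 2 `O=C(Nc1ccc(S(=O)(=O)Nc2ccccc2)cc1)c1ccc(Cl)cc1F`, the only measured member, gives 57% in this assay. Compound 3 `Cc1ccccc1NS(=O)(=O)c1ccc(NC(=O)c2ccc(Cl)cc2Cl)cc1` differs from compound 1 by 2-methylphenyl in place of benzoyl on a sulfonamide nitrogen. Among the compounds with values here, no step between measured compounds is at hand, so the size of the step from compound 1 to compound 3 in this assay has no reference and its direction is open. The expectation for compound 3 rests on compound 2, whose value 57% is the only anchor. Compound 3 is expected to reach about 55% in this assay, within a range from 20% to 90%.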

Compound 3, largest response reached (Emax), in percent of the reference or control that the assay uses: 32%
Compound 3: the middle estimate sits 23 percentage points above what was measured; the measured number falls inside the stated range.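

In this assay no step can be read from compound 1 to compound 3. The compounds shown leave open how benzoyl and 2-methylphenyl on the sulfonamide nitrogen compare in maximal response. No measured evidence bears on this result.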